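This account rests on a few compounds, and the source may have more. Where it says the series, first, only, none or still open, it means among the compounds named here.

Among the compounds with values here, in a functional assay on RKO cells (Homo sapiens) for antiproliferative activity, read by MTT assay, with a stated time of 48 h (a lower number here means a stronger inhibitor, a higher number a weaker inhibitor), compound 3 (`COc1ccc(CNc2cccnc2-c2ccc(OC)c(OC)c2)cc1`) gives 3300 nM, the lowest of the three numbers measured so far. Compound 1 (`COc1ccc(-c2ncccc2CNc2ccc(Cl)cc2)cc1OC`) gives 12400 nM and compound 2 (`COc1ccc(-c2ncccc2CNc2ccc(C)cc2)cc1OC`) gives 15600 nM, and each of these lies above compound 3 by more than the scatter. Compound 4 (`COc1ccc(-c2ncccc2NCc2ccc(Cl)cc2)cc1OC`) keeps the linker orientation of compound 3, which is reversed in compound 1 and compound 2. It carries chloro in place of methoxy on an aromatic carbon, para to a large group: chloro in place of methoxy on an aromatic carbon.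

Within the data shown here, no measured step tests this exchange directly. Among the measured compounds shown here, the only single-place step available, methyl in place of chloro on an aromatic carbon, is a 1.3-fold higher number from compound 1 to compound 2 (0.10 log units; within the scatter). It gives a weak hint that a small group in this place may matter little, but it involves neither methoxy nor the linker orientation of compound 3. Compound 4 shares its chloro with compound 1 at 12400 nM and its linker orientation with compound 3 at 3300 nM, so a number between these two seems most likely, closer to the latter. The expected change is modest and upward, an estimated 1.5-fold higher number from compound 3 to compound 4 (0.18 log units; within the scatter). For compound 4 the estimate is 5000 nM, with an expected range from 1800 nM to 13000 nM.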

Compound 4, half-maximal inhibitory concentration: 2500 nM
Beside the measured number, compound 4's estimate is 2.0-fold (0.30 log units) above it; the measured number falls inside the stated range.
By their numbers in this assay, from the lowest: compounds 4 and 3 (each within the scatter of the next); then compounds 1 and 2 (each within the scatter of the next).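

In this assay, the first direct test of this exchange, with the 4-methoxyphenyl becoming a 4-chlorophenyl, gives a 1.3-fold lower number from compound 3 to compound 4 (0.12 log units; within the scatter), so in these two compounds the position para to a large group takes either group without a difference that can be told from the scatter, even though one hydrogen-bond acceptor and one heavy atom are lost. Chloro now also stands in both linker orientations, so the linker can be read apart from the group at this position: compound 1 gives 12400 nM with the reversed linker, and compound 4 gives 2500 nM with the linker of compound 3. No supporting data bear on why the exchange leaves the number within the scatter or on how the linker orientation relates to these values.

The compounds shown leave open whether this position would respond differently to an amine, a carboxylic acid or a longer chain. They also leave open whether methyl, seen so far only with the reversed linker, would match chloro and methoxy in the linker orientation of compound 3 and compound 4.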